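Cytotoxicity of aryl hydrazones on the shared core

A few compounds are considered here, and "the series" means these few. Any claim that something is new, unique, unknown or untested is made for them only; others in the source may bear on it.

Going by the values given here, compound 3 `COc1ccccc1-c1nnc(-c2ccc(C(=O)N/N=C/c3ccc(Cl)cc3Cl)cc2)o1` gives the lowest of the three numbers so far in an ADME assay on THP-1 cells (Homo sapiens) for cytotoxicity (a higher number here means a weaker inhibitor, a lower number a stronger inhibitor), with a value of 78800 nM. Compound 1 `COc1ccccc1-c1nnc(-c2ccc(C(=O)N/N=C/c3cccc(O)c3)cc2)o1` gives 398000 nM in this assay, and compound 2 `COc1ccccc1-c1nnc(-c2ccc(C(=O)N/N=C/c3ccc(F)cc3)cc2)o1` gives 427000 nM; the step of a 1.1-fold higher number from compound 1 to compound 2 (0.03 log units; within the scatter) is within the scatter, so these two stand level. The steps to compound 3 are larger: a 5.1-fold lower number from compound 1 to compound 3 (0.70 log units; beyond the scatter) and a 5.4-fold lower number from compound 2 to compound 3 (0.73 log units; beyond the scatter), both beyond the scatter, which places compound 3 alone at the low end.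

Compound 4 `COc1ccccc1-c1nnc(-c2ccc(C(=O)N/N=C/c3c(O)cc(O)cc3O)cc2)o1` has not yet been measured in this assay. The change is 2,4,6-trihydroxyphenyl in place of 2,4-dichlorophenyl on a carbon with a double bond to nitrogen. The two steps that bear on it are the ones into compound 3, read in reverse: moving from a hydroxyphenyl (compound 1) or a fluorophenyl (compound 2) to the dichlorophenyl lowered the number modestly, so moving from the dichlorophenyl to a hydroxyl-bearing phenyl is expected to raise it by a similar amount, back toward the level of compound 1 and compound 2. The expected step is a 5.1-fold higher number from compound 3 to compound 4 (0.71 log units; beyond the scatter). On that basis compound 4 is estimated at 400000 nM in this assay, with a range from 150000 nM to 1000000 nM.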

Compound 4, half-maximal inhibitory concentration: 12400 nM
Beside the measured number, compound 4's estimate is 32-fold (1.51 log units) above it, outside the stated range (below it).
By their numbers in this assay, from the lowest: compound 4; then compound 3; then compounds 1 and 2 (each within the scatter of the next).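

At this position, on a carbon with a double bond to nitrogen, the 2,4,6-trihydroxyphenyl group sets a new low end for the series in this assay, with a 6.4-fold lower number from compound 3 to compound 4 (0.80 log units; beyond the scatter), so the 2,4-dichlorophenyl group no longer gives the lowest number. A hydroxyl on the ring does not by itself set the level: a 32-fold lower number from compound 1 to compound 4 (1.51 log units; beyond the scatter) and a 34-fold lower number from compound 2 to compound 4 (1.54 log units; beyond the scatter) are both large steps, yet compound 1, which also carries a hydroxyl, stands level with compound 2 and so goes against any simple rule that hydroxyl lowers the number. Nothing available explains why this one group separates so far from the others.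

The compounds shown leave open whether the low number of compound 4 follows from how many hydroxyl groups the ring carries or from where they stand, as only the 3-hydroxyphenyl and 2,4,6-trihydroxyphenyl groups represent hydroxyl here. A dihydroxyphenyl group would bear on that question, while an aminophenyl group or a phenyl group carrying a carboxylic acid would show whether groups other than hydroxyl can reach the same level.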